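Swapping Bromo for Methoxy in a Narrow Series

This account rests on a few compounds, and the source may have more. Where it says the series, first, only, none or still open, it means among the compounds named here.

In a functional assay on SGC-7901 cells (Homo sapiens) for antiproliferative activity, read by MTT assay, with a stated time of 48 h (on this read-out higher numbers stand for weaker inhibition and lower numbers for stronger inhibition), compound 1 `CC(=O)N1N=C(c2ccccc2)CC1c1ccc2c(c1)OCCO2` gives 50200 nM. Compound 2 `CC(=O)N1N=C(c2ccc(Cl)cc2)CC1c1ccc2c(c1)OCCO2` gives 59500 nM, and compound 3 `CC(=O)N1N=C(c2ccc(Br)cc2)CC1c1ccc2c(c1)OCCO2` gives 52300 nM. These values lie within the scatter of one another, so compound 3 has no distinct rank. Compound 4 `COc1ccc(C2=NN(C(C)=O)C(c3ccc4c(c3)OCCO4)C2)cc1` has methoxy in place of bromo on an aromatic carbon. Chloro in place of hydrogen gave a 1.2-fold higher number from compound 1 to compound 2 (0.07 log units; within the scatter), bromo in place of hydrogen gave a 1.0-fold higher number from compound 1 to compound 3 (0.02 log units; within the scatter), and bromo in place of chloro gave a 1.1-fold lower number from compound 2 to compound 3 (0.06 log units; within the scatter). None of these steps involves methoxy, so they are only indirect guides. No change beyond the scatter is therefore expected in this assay, and the estimated step is a 1.0-fold lower number from compound 3 to compound 4 (0.02 log units; within the scatter). For compound 4, the estimated value is 50000 nM, with an expected range of 27000 nM to 92000 nM.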

Compound 4, half-maximal inhibitory concentration: 45800 nM
Compound 4: the middle estimate sits 1.1-fold (0.04 log units) above what was measured, within the range that was stated.
By their numbers in this assay, from the lowest: compounds 4, 1, 3 and 2 (each within the scatter of the next).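

In this assay, among these compounds, the steps to methoxy, the first group here that is not a halogen or hydrogen and that brings an oxygen and a hydrogen-bond acceptor, all stay within the scatter: (a 1.1-fold lower number from compound 3 to compound 4 (0.06 log units; within the scatter)), (a 1.3-fold lower number from compound 2 to compound 4 (0.11 log units; within the scatter)) and (a 1.1-fold lower number from compound 1 to compound 4 (0.04 log units; within the scatter)). So at this place on the ring, this assay does not separate the 4-methoxyphenyl compound from the bromo, chloro or unsubstituted ones. No supporting evidence explains this result. From the compounds shown here alone, whether an amine or a carboxylic acid at this place would shift the number beyond the scatter remains open. So does whether changes elsewhere on the shared core would do so.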